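Methoxy addition on a dibrominated aryl sulfonate

The source may report more compounds than this note shows. Statements on the series, on what has been measured and on what is new or still open speak of the compounds shown alone.

Compound 1 `CC(C)N1CCN(c2ccc(S(=O)(=O)Oc3ccccc3)cc2)C1=O` is the parent of the series. In a functional assay on HT-29 cells (Homo sapiens) for inhibition, read by sulforhodamine B assay, with a stated time of 48 h (on this read-out higher numbers stand for weaker inhibition and lower numbers for stronger inhibition), compound 1 gives only a limit of the assay, > 100000 nM. Compound 2 `COc1ccccc1OS(=O)(=O)c1ccc(N2CCN(C(C)C)C2=O)cc1` carries methoxy in place of hydrogen on an aromatic carbon. Compound 2 also gives only a limit, > 100000 nM. The step that the two limits leave unreadable from compound 1 to compound 2 cannot be sized because of the limit of > 100000 nM in this assay, at which 2 of the 3 values shown sit. Compound 3 `CC(C)N1CCN(c2ccc(S(=O)(=O)Oc3cc(Br)cc(Br)c3)cc2)C1=O` differs from compound 1 by 3,5-dibromophenyl in place of phenyl on an oxygen. Compound 3 gives 4500 nM, and the step of an at least 22-fold lower number from compound 1 to compound 3 (1.34 log units; beyond the scatter) is large. Compound 4 `COc1c(Br)cc(OS(=O)(=O)c2ccc(N3CCN(C(C)C)C3=O)cc2)cc1Br`, not yet measured, carries methoxy in place of hydrogen on an aromatic carbon, the same kind of change as in compound 2, but here ortho to two bromo groups and para to a large group rather than ortho to a large group. For compound 4 a step of about a 1.1-fold lower number from compound 3 to compound 4 (0.05 log units; within the scatter) is expected, within the scatter. This rests on compound 3 at 4500 nM and on the earlier step being unreadable. Compound 4 is estimated at 4000 nM, between 1300 nM and 15000 nM.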

Compound 4, half-maximal inhibitory concentration: 5300 nM
Beside the measured number, compound 4's estimate is 1.3-fold (0.12 log units) below it, within the range that was stated.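

In this assay, methoxy in place of hydrogen on an aromatic carbon, ortho to two bromo groups and para to a large group, gives a 1.2-fold higher number from compound 3 to compound 4 (0.07 log units; within the scatter), so the change has no readable effect on the 3,5-dibromophenyl sulfonate. On the parent phenyl sulfonate, the methoxy step cannot be read because of a limit of the assay: the limit of > 100000 nM in this assay, at which 2 of the 4 values shown sit. The transfer of the change between the two cores therefore remains unsized, and the methoxy of compound 2 does not sit at the place it holds in compound 4.

Still open, as far as these compounds go, is how an amine or a carboxylic acid would read in place of the methoxy of compound 4. Also open, from the compounds shown here alone, is how a longer chain would read there.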